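From ethylpiperazine to an open diamine tail

A few compounds are considered here, and "the series" means these few. Any claim that something is new, unique, unknown or untested is made for them only; others in the source may bear on it.

Measured in an ADME assay on BaF3 cells (Mus musculus) for antiproliferative activity, read by CCK-8 assay, with a stated time of 72 h; a higher number here means a weaker inhibitor of growth, a lower number a stronger inhibitor of growth:
Compound 1 `COc1ccc(NC(=O)CCSc2ccc3c(/C=C/c4ccccn4)n[nH]c3c2)cc1C(F)(F)F`: > 10000 nM (a limit of the assay)
Compound 2 `CN1CCN(Cc2ccc(NC(=O)CCSc3ccc4c(/C=C/c5ccccn5)n[nH]c4c3)cc2C(F)(F)F)CC1`: 2480 nM
Compound 3 `CCN1CCN(Cc2ccc(NC(=O)CCSc3ccc4c(/C=C/c5ccccn5)n[nH]c4c3)cc2C(F)(F)F)CC1`: 840 nM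

Compound 3 holds the lowest number in this assay, at 840 nM, and compound 2 lies nearest at 2480 nM. Compound 1 gives only a limit.

Compound 4 `CN(C)CCN(C)Cc1ccc(NC(=O)CCSc2ccc3c(/C=C/c4ccccn4)n[nH]c3c2)cc1C(F)(F)F` keeps the shared core and alters only the tail: (2-(dimethylamino)ethyl)(methyl)amino in place of 4-ethylpiperazin-1-yl on a saturated chain carbon bound to an aromatic carbon. That is, (2-(dimethylamino)ethyl)(methyl)amino stands in place of 4-ethylpiperazin-1-yl on a saturated chain carbon bound to an aromatic carbon.

Among the measured compounds shown here, three measured steps bear on this change. Adding the tail gave an at least 4.0-fold lower number from compound 1 to compound 2 (0.60 log units; beyond the scatter) and an at least 11-fold lower number from compound 1 to compound 3 (1.07 log units; beyond the scatter), so the number responds strongly to this part of the molecule. A single added methyl on the tail gave a 3.0-fold lower number from compound 2 to compound 3 (0.47 log units; beyond the scatter). For the measured compounds named here, no measured compound has an open-chain tail. A modest rise, similar in size to the step from the methyl, is therefore expected rather than a large one.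

In this assay the expected step is a 2.4-fold higher number from compound 3 to compound 4 (0.38 log units; beyond the scatter). For compound 4 the estimated value is 2000 nM, with an expected range of 600 nM to 6000 nM.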

Compound 4, concentration for 50% growth inhibition: 1850 nM
Compound 4: middle estimate off by 1.1-fold (0.03 log units), on the high side, and the stated range covers the measured number.
By their numbers in this assay, from the lowest: compound 3; then compounds 4 and 2 (each within the scatter of the next). At a limit, above all of these: compound 1.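

In this assay, the tail does not need a ring to improve on the methoxy group, as the open chain gives an at least 5.4-fold lower number from compound 1 to compound 4 (0.73 log units; beyond the scatter). That step is only a bound, since compound 1 gives a limit of the assay: the limit of > 10000 nM in this assay, at which 1 of the 4 values shown sits.

The open chain falls short of the ethylpiperazine tail, with a 2.2-fold higher number from compound 3 to compound 4 (0.34 log units; beyond the scatter), yet it cannot be told apart from the methylpiperazine tail, with a 1.3-fold lower number from compound 2 to compound 4 (0.13 log units; within the scatter), so among these tails only 4-ethylpiperazin-1-yl stands out.

The compounds shown leave open whether an isopropyl or a 2-hydroxyethyl group on the piperazine would carry the gain from methyl to ethyl further. They also leave open whether a diethylamino end on the open chain would do for that tail what ethyl did for the piperazine, or whether a morpholine would hold any of the gain.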